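A few compounds are considered here, and "the series" means these few. Any claim that something is new, unique, unknown or untested is made for them only; others in the source may bear on it.

Compound 1 `O=C(Nc1ccc(Oc2ccnc3[nH]ccc23)c(F)c1)c1nn(-c2ccccc2)ccc1=O` gives 56800 nM in a functional assay on A549 cells (Homo sapiens) for cytotoxicity, read by MTT assay, with a stated time of 72 h; on this read-out higher numbers stand for weaker inhibition and lower numbers for stronger inhibition. Compound 2 `Cn1ccc2c(Oc3ccc(NC(=O)c4nn(-c5ccc(Br)cc5)ccc4=O)cc3F)ccnc21` is reported only as a limit of this assay, > 60000 nM, where (the limit of > 60000 nM in this assay, at which 1 of the 2 values shown sits). Compound 3 `Cn1ccc2c(Oc3ccc(NC(=O)c4nn(-c5ccccc5)ccc4=O)cc3F)ccnc21` has not been measured in this assay. It differs from compound 2 by hydrogen in place of bromo on an aromatic carbon. No single-point step between measured compounds is shown here; the two values of compound 1 and compound 2 both sit at the weak end, and the change from compound 2 to compound 3 is expected to move the read-out by a number no higher from compound 2 to compound 3 (the limit leaves the size open), not beyond the scatter. Compound 3 is therefore estimated at 60000 nM, within 25000 nM to 150000 nM.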

Compound 3, half-maximal inhibitory concentration: > 60000 nM
Compound 3: only a limit was reported; the forecaster's own chance of this, stated with the estimate: 50%; the middle value sits exactly at the limit.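

Like compound 2, compound 3 is reported only as a limit, so the phenyl and 4-bromophenyl compounds cannot be told apart and the step between them cannot be read: the limit of > 60000 nM in this assay, at which 2 of the 3 values shown sit. In this assay, methyl in place of hydrogen on an aromatic nitrogen gives an at least 1.0-fold higher number from compound 1 to compound 3 (0.02 log units; that floor lies within the scatter), so this floor does not separate the two compounds. Going by these compounds, what bromo contributes at this position therefore stays open. So does whether an amine or a carboxylic acid at the same place on the phenyl ring would bring a compound to a readable value.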